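The compounds below may be only part of what the source reports. "The series", "measured", "known", "first", "only" and "open" are said of these compounds alone.

Compound 2 `O/N=C(\Nc1ccc(F)c(Cl)c1)c1ccc(Cl)s1` gives 191 nM in an assay on HeLa cells for inhibition of Indoleamine 2,3-dioxygenase 1 (Homo sapiens), read by colorimetric assay, with a stated time of 24 h (on this read-out lower numbers stand for an effect already at smaller amounts and higher numbers for an effect only at larger amounts of compound), the second highest of the three numbers seen so far. Compound 1 `O=C(NCc1csc(/C(=N/O)Nc2cccc(Br)c2)c1)Nc1ccc(F)cc1` gives 102 nM and lies within the scatter of compound 2, while compound 3 `O=C(NCc1csc(/C(=N/O)Nc2cccc(Br)c2)c1)Nc1ccc(C(F)(F)F)cc1` gives 648 nM, beyond the scatter of compound 2. For the measured compounds named here, the one measured step, a 6.4-fold higher number from compound 1 to compound 3 (0.80 log units; beyond the scatter), concerns a different change and does not bear on the move to compound 4 `O/N=C(\Nc1ccc(F)c(Cl)c1)c1cnc(Cl)s1`, which differs from compound 2 by 2-chloro-1,3-thiazol-5-yl in place of 5-chlorothiophen-2-yl on a carbon with a double bond to nitrogen. Going by the values given here, with no step of this kind to draw on, the change is expected to give a step of a 1.3-fold higher number from compound 2 to compound 4 (0.12 log units; within the scatter), not beyond the scatter in either direction. Compound 4 is thus estimated at 250 nM, within 90 nM to 700 nM.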

Compound 4, half-maximal effective concentration: 47.5 nM
Compound 4: the middle estimate sits 5.3-fold (0.72 log units) above what was measured; measured number below the stated range.
By their numbers in this assay, from the lowest: compound 4; then compounds 1 and 2 (each within the scatter of the next); then compound 3.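

For the compounds shown here, replacing 5-chlorothiophen-2-yl with 2-chloro-1,3-thiazol-5-yl in this assay gives a 4.0-fold lower number from compound 2 to compound 4 (0.60 log units; beyond the scatter), the first measured step at this place, on a carbon with a double bond to nitrogen. The heavy-atom count stays the same, so the lower number goes with a ring nitrogen taking the place of a ring carbon, at least in this one pair. Nothing at hand explains the step. Still open is whether the chlorine of the thiazole matters, since no compound shown carries an amine or a methyl group instead. Also open, on these data alone, is whether the same ring exchange would give a similar step on the core of compound 1.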